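The source may hold more compounds than are shown below. What is called first, only, known or untested is meant among the compounds shown, and "the series" means these compounds.

Measured in a functional assay on CHO-K1 cells for antagonist activity at transient receptor potential cation channel subfamily V member 1 (Homo sapiens), read by FLIPR; a higher number here means a weaker inhibitor, a lower number a stronger inhibitor:
compound 1 `Cc1ccc(Nc2nc(C(F)(F)F)ccc2CNC(=O)C(C)c2ccc(NS(C)(=O)=O)c(F)c2)cc1C`, 1160 nM
compound 2 `CC(C(=O)NCc1ccc(C(F)(F)F)nc1N(C)C)c1ccc(NS(C)(=O)=O)c(F)c1`, 2390 nM
compound 3 `CC(C(=O)NCc1ccc(C(F)(F)F)nc1N(C)c1ccccc1)c1ccc(NS(C)(=O)=O)c(F)c1`, 57.4 nM

Compound 1 gives the second highest of the three numbers; nearest stands compound 2 at a 2.1-fold higher number from compound 1 to compound 2 (0.31 log units; beyond the scatter), furthest compound 3 at a 20-fold lower number from compound 1 to compound 3 (1.31 log units; beyond the scatter). Compound 4 `CC(C(=O)NCc1ccc(C(F)(F)F)nc1N1CC=CCC1)c1ccc(NS(C)(=O)=O)c(F)c1` differs from compound 1 thus: a group of 6 heavy atoms (5 carbon, 1 nitrogen; one six-membered non-aromatic ring with 1 hetero atom) in place of a group of 9 heavy atoms (8 carbon, 1 nitrogen; one six-membered aromatic ring of carbon only), on an aromatic carbon. Going by the values given here, two measured steps bear on this change: a 2.1-fold higher number from compound 1 to compound 2 (0.31 log units; beyond the scatter), dimethylamino in place of (3,4-dimethylphenyl)amino, and a 42-fold lower number from compound 2 to compound 3 (1.62 log units; beyond the scatter), phenyl in place of methyl on a nitrogen on an aromatic ring. The entering group of compound 4 holds no aromatic ring and no hydrogen-bond donor, which places it nearer compound 2 than compound 3. A modest rise in the number is therefore expected: a 1.7-fold higher number from compound 1 to compound 4 (0.24 log units; within the scatter). Compound 4 is estimated at 2000 nM, with a range from 700 nM to 6000 nM.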

Compound 4, half-maximal inhibitory concentration: 12.1 nM
The estimate for compound 4 lay 170-fold (2.22 log units) above the measured number; the whole stated range lies above it.
By their numbers in this assay, from the lowest: compound 4; then compound 3; then compound 1; then compound 2.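

At this position, next to the ring nitrogen, a six-membered non-aromatic ring gives the lowest number of the set in this assay: a 96-fold lower number from compound 1 to compound 4 (1.98 log units; beyond the scatter), a 200-fold lower number from compound 2 to compound 4 (2.30 log units; beyond the scatter) and a 4.7-fold lower number from compound 3 to compound 4 (0.68 log units; beyond the scatter). An aromatic ring in this group is thus not required for a low number, and the absence of a hydrogen-bond donor goes with lower numbers in compound 3 and compound 4, but not in compound 2. No available evidence accounts for this result.

From the compounds shown here alone, the role of the double bond in the ring of compound 4 stays open. So does whether a piperidine, morpholine or pyrrolidine ring here would match compound 4.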